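Anilide to Chloropyridinyl Amide: Expected Cytotoxicity Tolerance

The source may report more compounds than this note shows. Statements on the series, on what has been measured and on what is new or still open speak of the compounds shown alone.

Three compounds sharing one core have been examined in an ADME assay on MT4 cells (Homo sapiens) for cytotoxicity, read by MTT assay; a lower number here means that less compound is tolerated, a higher number that more compound is tolerated. Compound 1 `O=C(CSc1nncnc1-c1cccc2ccccc12)N1CCc2ccccc2C1` gives 13000 nM in this assay. Compound 2 `O=C(CSc1nncnc1-c1ccccc1Cl)Nc1ccccc1` gives 127000 nM in this assay, and compound 3 `Cc1ccc(NC(=O)CSc2nncnc2-c2ccccc2Cl)c([N+](=O)[O-])c1` gives 158000 nM. Among these three numbers compound 2 stands second highest. Its nearest neighbour is compound 3, whose number lies within the usual scatter of that of compound 2, so no order between the two can be read. Its furthest is compound 1, whose number is lower by a margin beyond the scatter.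

Compound 4 `O=C(CSc1nncnc1-c1ccccc1Cl)Nc1cccnc1Cl` has not yet been measured in this assay. It differs from compound 2 in one place: 2-chloropyridin-3-yl in place of phenyl on an amide-type nitrogen. Among the measured compounds shown here, no pair of measured compounds that differ in only one place is available, so the size of such a step cannot be read from the numbers in hand. For the measured compounds named here, the only guidance is that compound 2 and compound 3 give numbers within the scatter of each other. The step from compound 2 to compound 4 is therefore expected to be small, a 1.3-fold lower number from compound 2 to compound 4 (0.10 log units; within the scatter), with no direction beyond the scatter. Compound 4 is expected to give about 100000 nM in this assay, between 40000 nM and 250000 nM.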

Compound 4, half-maximal cytotoxic concentration: 167000 nM
The estimate for compound 4 lay 1.7-fold (0.22 log units) below the measured number, and the stated range covers the measured number.
By their numbers in this assay, from the lowest: compound 1; then compounds 2, 3 and 4 (each within the scatter of the next).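

In this assay, among the compounds shown here, putting 2-chloropyridin-3-yl in place of phenyl on an amide-type nitrogen gives a 1.3-fold higher number from compound 2 to compound 4 (0.12 log units; within the scatter), the first direct reading of a change at this position. The step shows that, in this pair, a ring with one hetero atom and a chlorine can take the place of a ring of carbon only without a difference that can be told from the scatter. Nothing available bears on why the step is this small.

From the compounds shown here alone, whether the same holds for a carboxylic acid, an amine or a longer chain on this nitrogen stays open. Compound 1 differs from the others in more than one place, so steps involving it cannot be read, and what sets its number apart remains unresolved.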